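A few compounds are considered here, and "the series" means these few. Any claim that something is new, unique, unknown or untested is made for them only; others in the source may bear on it.

In an ADME assay on MT2 cells (Homo sapiens) for cytotoxicity (a higher number here means that more compound is tolerated, a lower number that less compound is tolerated), compound 1 `CC(C)=CCOc1cc(Nc2ncnc(Cl)n2)ccc1Cl` gives 45000 nM. Among the compounds with values here, the only other compound measured, compound 2 `CC(C)=CCOc1cc(Nc2nc(C)nc(Cl)n2)ccc1Cl`, gives 40000 nM in this assay, so that a 1.1-fold lower number from compound 1 to compound 2 (0.05 log units; within the scatter) describes the sole known step, a single methyl on the shared core. Compound 3 `CC(C)=CCOc1cc(Nc2ncnc(Cl)n2)ccc1C#N` differs from compound 1 as follows: cyano in place of chloro on an aromatic carbon. Within the data shown here, no measured step shares this exchange; the one known step touches another part of the core and stayed within the scatter. This exchange is therefore expected to move this assay little, with no change at the digits printed from compound 1 to compound 3 (within the scatter) as the estimated step. Compound 3 is expected to give 45000 nM, within 20000 nM to 100000 nM.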

Compound 3, half-maximal cytotoxic concentration: > 100000 nM
Compound 3: only a limit was reported; the forecaster's own chance of this, stated with the estimate: 30%; at least 2.2-fold (0.34 log units) between middle value and limit.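

In this assay, the cyano for chloro exchange on the aromatic carbon ortho to the (3-methylbut-2-en-1-yl)oxy group gives an at least 2.2-fold higher number from compound 1 to compound 3 (0.34 log units; beyond the scatter). This is the first step shown to lie beyond the scatter, so this carbon is a place where a single exchange can shift the tolerated concentration, which the methyl step on another part of the core did not show. The value of compound 3 is a limit, not a number: the limit of > 100000 nM in this assay, at which 1 of the 3 values shown sits.

On these data alone, how far compound 3 lies past that limit stays open. So does whether an amine, a carboxylic acid or a methoxy group on this same carbon would move the number in the same direction.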